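Swapping an amine for an amide: what happens to cytotoxicity

This account rests on a few compounds, and the source may have more. Where it says the series, first, only, none or still open, it means among the compounds named here.

Measured compounds:
- Compound 1, `CC(C)CCn1c(Cn2c(=O)n(C(C)C)c3ccccc32)nc2cc(CNC3CC3)ccc21`: 17200 nM
- Compound 2, `CC(C)CCn1c(Cn2c(=O)n(CC(=O)OC(C)(C)C)c3ccccc32)nc2cc(C(=N)N)ccc21`: 7900 nM
- Compound 3, `CC(C)CCn1c(Cn2c(=O)n(C(C)C)c3ccccc32)nc2ccc(C#N)cc21`: 10000 nM

These three compounds share a core and were tested in an ADME assay on HEp-2 cells (Homo sapiens) for cytotoxicity; a lower number here means that less compound is tolerated, a higher number that more compound is tolerated. Compound 1 stands at the top of the three numbers, but its gap to compound 3 lies within the usual scatter of repeated measurements, so the two cannot be told apart; only the gap to compound 2 is beyond the scatter.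

The next compound, compound 4, `CC(C)CCn1c(Cn2c(=O)n(C(C)C)c3ccccc32)nc2cc(C(=O)N(C)C)ccc21`, has not yet been measured in this assay. It differs from compound 1 in one place: dimethylcarbamoyl in place of (cyclopropylamino)methyl on an aromatic carbon. For the measured compounds named here, no pair among the measured compounds differs in just this way, so there is no measured step to lean on.

With nothing in the data pointing in either direction, the expectation for compound 4 is a step of a 1.1-fold lower number from compound 1 to compound 4 (0.06 log units; within the scatter) from compound 1 in this assay, which is no change beyond the scatter. Compound 4 is therefore estimated at 15000 nM, with a likely range from 7000 nM to 35000 nM.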

Compound 4, half-maximal cytotoxic concentration: 25600 nM
Beside the measured number, compound 4's estimate is 1.7-fold (0.23 log units) below it; low and high end bracket the measured number.
By their numbers in this assay, from the lowest: compounds 2, 3, 1 and 4 (each within the scatter of the next, the first and the last beyond it).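

In this assay, putting dimethylcarbamoyl in place of (cyclopropylamino)methyl on this aromatic carbon gives a 1.5-fold higher number from compound 1 to compound 4 (0.17 log units; within the scatter), so the two compounds cannot be told apart. For the compounds shown here, this is the first single-place comparison in the set, and it shows that this position can go from an amine carrying a three-membered ring and a hydrogen-bond donor to an amide with no ring and no donor without a change beyond the scatter. Nothing at hand bears on why the number stays within the scatter.

A carboxylic acid or a primary amine on this same carbon could still give a different result. This single pair also leaves open whether the same swap would behave alike on a compound with a different group in place of the isopropyl on the shared core.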